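Swapping the aryl group on the shared core of compound 1

This account rests on a few compounds, and the source may have more. Where it says the series, first, only, none or still open, it means among the compounds named here.

Of the compounds shown here, three built on one core have been measured so far. Compound 1 `CC(c1ccc(-c2ccccc2)c(F)c1)c1nnc2n1N=C(c1ccc(OC(F)(F)F)cc1)CS2` is tested in a functional assay on HCT-116 cells (Homo sapiens) for inhibition, read by sulforhodamine B assay, with a stated time of 72 h (on this read-out higher numbers stand for weaker inhibition and lower numbers for stronger inhibition), and gives 5400 nM. Compound 3 `CC(C)Cc1ccc(C(C)c2nnc3n2N=C(c2ccc(Cl)cc2)CS3)cc1` gives 6700 nM in this assay, a number that sits within the scatter of compound 1. Compound 2 `COc1ccc2cc(C(C)c3nnc4n3N=C(c3ccc(OC(F)(F)F)cc3)CS4)ccc2c1` gives 11700 nM in this assay, which lies beyond the scatter of compound 1. On these three numbers compound 1 has the lowest value, with compound 3 close to it and compound 2 further away.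

Compound 4 `CC(c1ccc(-c2ccccc2)c(F)c1)c1nnc2n1N=C(c1ccc(Cl)cc1Cl)CS2` has not yet been measured. It differs from compound 1 in one place: 2,4-dichlorophenyl in place of 4-(trifluoromethoxy)phenyl on a carbon with a double bond to nitrogen. Among the compounds with values here, the only comparison in hand for a change at this position is indirect, since compound 1 and compound 3 differ in more than one place, yet their values lie within the scatter of each other.

Within the data shown here, no step for this change has been measured, so nothing beyond the scatter is expected in either direction for compound 4. The step from compound 1 to compound 4 in this assay is estimated as a 1.1-fold higher number from compound 1 to compound 4 (0.05 log units; within the scatter). Compound 4 is therefore expected to give about 6000 nM in this assay, within a range from 2500 nM to 15000 nM.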

Compound 4, half-maximal inhibitory concentration: 6900 nM
The estimate for compound 4 lay 1.2-fold (0.06 log units) below the measured number, and the stated range covers the measured number.
By their numbers in this assay, from the lowest: compounds 1, 3, 4 and 2 (each within the scatter of the next, the first and the last beyond it).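

In this assay, within the data shown here, the exchange of 4-(trifluoromethoxy)phenyl for 2,4-dichlorophenyl on a carbon with a double bond to nitrogen gives the first direct reading for this position, with the rest of compound 1 held the same: a 1.3-fold higher number from compound 1 to compound 4 (0.11 log units; within the scatter) is the step, and the two compounds cannot be told apart on this read-out. The position thus holds either aryl group without a step beyond the scatter, even though the entering group has no oxygen, no fluorine and no hydrogen-bond acceptor, while it carries two chlorine atoms and fewer heavy atoms than the group it replaces. No measurement in hand goes beyond these numbers to account for the result.

This single step, read on one group at the other end of the shared core, leaves open whether the same holds when that other group is different. It also leaves open whether this position would stay as undemanding with something other than a halogen- or fluoroalkoxy-bearing phenyl ring, such as a phenyl ring carrying an amine or a carboxylic acid, or a longer chain in place of the ring.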